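Swapping 2-bromophenyl for 2,4-difluorophenyl: what to expect

The source may hold more compounds than are shown below. What is called first, only, known or untested is meant among the compounds shown, and "the series" means these compounds.

Compound 1 `Cc1cc(Nc2nc(NCc3ccccc3Cl)nc3[nH]ncc23)n[nH]1`: 4130 nM
Compound 2 `Cc1cc(Nc2nc(NCc3ccccc3Br)nc3[nH]ncc23)n[nH]1`: 14100 nM

Among the measured compounds shown here, in a functional assay on MCF7 cells (Homo sapiens) for inhibition, read by MTT assay, with a stated time of 5 days (on this read-out lower numbers stand for stronger inhibition and higher numbers for weaker inhibition), compound 2 gives 14100 nM, the higher of the two numbers measured so far, and so the weaker inhibition of the pair. Compound 3 `Cc1cc(Nc2nc(NCc3ccc(F)cc3F)nc3[nH]ncc23)n[nH]1` keeps the shared core but changes the group at the end of the side chain: 2,4-difluorophenyl in place of 2-bromophenyl on a saturated chain carbon bound to a nitrogen on an aromatic ring. Put simply, 2,4-difluorophenyl stands in place of 2-bromophenyl on a saturated chain carbon bound to a nitrogen on an aromatic ring.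

For the measured compounds named here, only one measured step bears on this change. It is a 3.4-fold higher number from compound 1 to compound 2 (0.53 log units; beyond the scatter), a modest step beyond the scatter, for bromo in place of chloro on an aromatic carbon. Compound 3 gives up that bromo, so a modest move towards a lower number in this assay seems more likely than a rise. Going by the values given here, this is a weak guide, since no compound carrying fluorine has been measured yet. The estimated change is a 2.4-fold lower number from compound 2 to compound 3 (0.37 log units; beyond the scatter). For compound 3 the expected value is 6000 nM, with an estimated range from 1800 nM to 20000 nM.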

Compound 3, half-maximal inhibitory concentration: 670 nM
The estimate for compound 3 lay 9.0-fold (0.95 log units) above the measured number; the whole stated range lies above it.
By their numbers in this assay, from the lowest: compound 3; then compound 1; then compound 2.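

In this assay, the group at the end of the side chain can move the number much further than the earlier swap of chloro for bromo suggested: the change to 2,4-difluorophenyl gives a 21-fold lower number from compound 2 to compound 3 (1.32 log units; beyond the scatter), a large step, whereas the earlier step was only modest. The gain is not simply a matter of losing bromo, as the same group set against 2-chlorophenyl gives a 6.2-fold lower number from compound 1 to compound 3 (0.79 log units; beyond the scatter), which also lies beyond the scatter. Compound 3 is therefore the strongest inhibitor of the three, and this place, on a saturated chain carbon bound to a nitrogen on an aromatic ring, proves sensitive to which halogens the ring carries, with the shared core left unchanged.

Nothing at hand gives a reason for the gain, so the result stands as an observation only. As far as these compounds go, it also remains open whether both fluorines are needed, and a phenyl ring with a single fluorine, a bare phenyl ring, or one carrying a methoxy group or an amine would help to separate what each change contributes.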